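A few compounds are considered here, and "the series" means these few. Any claim that something is new, unique, unknown or untested is made for them only; others in the source may bear on it.

Measured in a functional assay (muscle tissue) with Cavia porcellus as the target; on this read-out lower numbers stand for an effect already at smaller amounts and higher numbers for an effect only at larger amounts of compound:
- compound 1 `COC(=O)C1=C(C)N=C(C)/C(=C(\O)OC)C1c1ccc(Cl)cc1`: 8130 nM
- compound 2 `COC(=O)C1=C(C)N=C(C)/C(=C(\O)OC)C1c1cc(Cl)cc(Cl)c1`: 93.3 nM
- compound 3 `COC(=O)C1=C(C)N=C(C)/C(=C(\O)OC)C1c1cccc(Br)c1`: 1.29 nM

Of these three, compound 3 has the lowest number, at 1.29 nM. The nearest to it is compound 2, with a 72-fold lower number from compound 2 to compound 3 (1.86 log units; beyond the scatter), and the furthest is compound 1, with a 6300-fold lower number from compound 1 to compound 3 (3.80 log units; beyond the scatter).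

The next compound is compound 4 `COC(=O)C1=C(C)N=C(C)/C(=C(\O)OC)C1c1cccc([N+](=O)[O-])c1`, which keeps the shared core and replaces the bromo of compound 3 with a nitro on an aromatic carbon: nitro in place of bromo on an aromatic carbon.

For the measured compounds named here, no measured step makes this exact swap, so the data give no direct guide to it. All three measured steps are large, including an 87-fold lower number from compound 1 to compound 2 (1.94 log units; beyond the scatter), and they show that in these compounds this assay responds strongly to changes on the aromatic ring. However, each of those steps alters where the ring carries its groups or how many it carries, whereas here one group simply takes the place of another. A much smaller step is therefore expected, most likely towards a somewhat higher number, since compound 3 already stands lowest at 1.29 nM. This expectation remains uncertain, and a shift in either direction is possible.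

The expected step is a 3.1-fold higher number from compound 3 to compound 4 (0.49 log units; beyond the scatter). For compound 4 the estimated value is 4 nM, with an expected range of 0.8 nM to 25 nM.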

Compound 4, half-maximal effective concentration: 3.98 nM
The estimate for compound 4 lay 1.0-fold (0.00 log units) above the measured number; the measured number falls inside the stated range.
By their numbers in this assay, from the lowest: compound 3; then compound 4; then compound 2; then compound 1.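

For the compounds shown here, compound 4 gives the first reading of one group taking the place of another at a single spot on the aromatic ring, meta to a large group, and in this assay nitro in place of bromo brings a 3.1-fold higher number from compound 3 to compound 4 (0.49 log units; beyond the scatter). This step is modest beside a 6300-fold lower number from compound 1 to compound 3 (3.80 log units; beyond the scatter), in which the bromo sits at a different place on the ring from the chloro it replaces, so at this position a bromine can give way to a nitro, with more heavy atoms and with hydrogen-bond acceptors, at a limited cost in this assay, though the cost still lies beyond the usual scatter. No measured evidence shown here bears on why the number moves by this amount.

The compounds shown leave open how far this tolerance extends at the same position, for example to an amine, a carboxylic acid or a longer chain such as propyl. They also leave open whether a chloro alone at this position would read like the bromo, which would help separate the effect of the group's identity from that of its place on the ring.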